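Second demethylation on the core of compound 3

A few compounds are considered here, and "the series" means these few. Any claim that something is new, unique, unknown or untested is made for them only; others in the source may bear on it.

Compound 3 `COc1ccc2[nH]c(-c3ccc(F)cc3)cc(=O)c2c1O` gives 2400 nM in a functional assay on HCT-116 cells (Homo sapiens) for cytotoxicity, read by MTT assay, with a stated time of 48 h (on this read-out higher numbers stand for weaker inhibition and lower numbers for stronger inhibition), and stands highest of the two numbers in this set. Compound 2 `COc1ccc2[nH]c(-c3ccccc3F)cc(=O)c2c1O` gives 50 nM in this assay, and the step of a 48-fold higher number from compound 2 to compound 3 (1.68 log units; beyond the scatter) follows only the exchange of the fluorophenyl group. Compound 1 `COc1ccc2[nH]c(-c3ccc(F)cc3)cc(=O)c2c1OC` gives > 20000 nM in this assay, which is a limit of the assay and not a number (the limit of > 20000 nM in this assay, at which 1 of the 3 values shown sits).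

Compound 4 `O=c1cc(-c2ccc(F)cc2)[nH]c2ccc(O)c(O)c12` differs from compound 3 by hydrogen in place of methyl on an oxygen on an aromatic ring. For the measured compounds named here, one measured step bears on it: the step of an at least 8.3-fold lower number from compound 1 to compound 3 (0.92 log units; beyond the scatter), which is the same exchange of methyl for hydrogen on the other oxygen of the shared core, with the 4-fluorophenyl group held fixed in both compounds. Its true size is not known beyond the limit it started from. A step of the same kind at the second oxygen is therefore expected to lower the number, though a size as large as that one cannot be assumed. Compound 4 is expected to give about 900 nM in this assay, within the range 200 nM to 4000 nM. That estimate means the step of a 2.7-fold lower number from compound 3 to compound 4 (0.43 log units; beyond the scatter) is expected, a modest decrease beyond the scatter.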

Compound 4, half-maximal inhibitory concentration: > 100000 nM
Compound 4 gave a limit, no number; the forecaster's own chance of this, stated with the estimate: 5%; middle value at least 110-fold (2.04 log units) away from the limit.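

Reading across the shared core in this assay, methoxy to hydroxy at this oxygen gives an at least 41-fold higher number from compound 3 to compound 4 (1.61 log units; beyond the scatter), whereas the same exchange at the other oxygen gives an at least 8.3-fold lower number from compound 1 to compound 3 (0.92 log units; beyond the scatter), so within these compounds the direction of the change depends on which oxygen carries it. With the 4-fluorophenyl group held fixed, only compound 3, which keeps one methoxy and one hydroxy, gives a number, 2400 nM. The result for compound 4 is a limit of the assay and not a number: the limit of > 100000 nM in this assay, at which 1 of the 4 values shown sits.

The result for compound 1 is likewise a limit of the assay and not a number, so the true size of neither step is known: the limit of > 20000 nM in this assay, at which 1 of the 4 values shown sits. The compounds shown do not say why the two oxygens part ways, whether the same exchange runs the same way with the 2-fluorophenyl group of compound 2, or how an amine or an ethoxy group at this oxygen would read.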